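The source may report more compounds than this note shows. Statements on the series, on what has been measured and on what is new or still open speak of the compounds shown alone.

Measured in a functional assay on MGC-803 cells (Homo sapiens) for inhibition, read by MTT assay; on this read-out higher numbers stand for weaker inhibition and lower numbers for stronger inhibition:
- compound 1 `C=C1C(=O)[C@@]23C(=O)OC[C@]4([C@@H](OC(C)=O)CCC(C)(C)[C@H]4C=O)[C@@H]2CC[C@H]1[C@H]3OC(=O)CC`: 3220 nM
- compound 2 `C=C1C(=O)[C@@]23C(=O)OC[C@]4([C@@H](OC(C)=O)CCC(C)(C)[C@H]4C=O)[C@@H]2CC[C@H]1[C@H]3OC(=O)c1ccc(OC)cc1`: 2530 nM
- compound 3 `C=C1C(=O)[C@@]23C(=O)OC[C@]4([C@@H](OC(C)=O)CCC(C)(C)[C@H]4C=O)[C@@H]2CC[C@H]1[C@H]3OC(=O)c1ccc([N+](=O)[O-])cc1`: 1980 nM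

Compound 3, at 1980 nM, cannot be separated from the other two compounds in this assay, as all three values lie within the scatter of one another. Compound 4 `C=C1C(=O)[C@@]23C(=O)OC[C@]4([C@@H](OC(C)=O)CCC(C)(C)[C@H]4C=O)[C@@H]2CC[C@H]1[C@H]3OC(=O)c1ccccc1` keeps the shared core and carries a benzoyl group, with hydrogen in place of nitro on an aromatic carbon.

For the measured compounds named here, three measured steps bear on this change. Nitro in place of methoxy gave a 1.3-fold lower number from compound 2 to compound 3 (0.11 log units; within the scatter). 4-Nitrophenyl in place of ethyl gave a 1.6-fold lower number from compound 1 to compound 3 (0.21 log units; within the scatter), and 4-methoxyphenyl in place of ethyl gave a 1.3-fold lower number from compound 1 to compound 2 (0.10 log units; within the scatter). None of these steps exceeds the scatter, so no step beyond the scatter is expected in either direction on removing the nitro group. The expected step is small: a 1.2-fold higher number from compound 3 to compound 4 (0.08 log units; within the scatter). For compound 4 the estimated value is 2400 nM, with an expected range from 1400 nM to 4000 nM.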

Compound 4, half-maximal inhibitory concentration: 2180 nM
The estimate for compound 4 lay 1.1-fold (0.04 log units) above the measured number, and the stated range covers the measured number.
By their numbers in this assay, from the lowest: compounds 3, 4, 2 and 1 (each within the scatter of the next).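

In this assay, the benzoyl compound supplies the hydrogen reference for the substituted rings: hydrogen in place of nitro gives a 1.1-fold higher number from compound 3 to compound 4 (0.04 log units; within the scatter) and hydrogen in place of methoxy gives a 1.2-fold lower number from compound 2 to compound 4 (0.06 log units; within the scatter) so neither group, on an aromatic carbon para to a large group, can be told from hydrogen on this read-out. The unsubstituted ring also cannot be told from the ethyl chain, since phenyl in place of ethyl gives a 1.5-fold lower number from compound 1 to compound 4 (0.17 log units; within the scatter) and all of these steps stay within the scatter. No measurement is available that would explain the result or show what else these changes do.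

The compounds shown leave open whether an amine or a carboxylic acid on the same aromatic carbon would move the number beyond the scatter. They also leave open whether a longer chain in place of ethyl, or a free hydroxyl in place of the whole ester, would do so.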